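Ring size on the sulfur: cyclopentyl to cyclohexyl

The compounds below may be only part of what the source reports. "The series", "measured", "known", "first", "only" and "open" are said of these compounds alone.

Of the compounds shown here, three sharing one core have been measured in an assay on CHO cells for antagonist activity at transient receptor potential cation channel subfamily V member 1 (Homo sapiens), read by FLIPR; a higher number here means a weaker inhibitor, a lower number a stronger inhibitor. Compound 1 `CC(C(=O)NCc1ccc(C(F)(F)F)cc1N1CCC(C)(C)CC1)c1ccc(NS(C)(=O)=O)c(F)c1` gives 1.3 nM, compound 2 `CC(C(=O)NCc1ccc(C(F)(F)F)cc1OC1CCCC1)c1ccc(NS(C)(=O)=O)c(F)c1` gives 0.6 nM, and compound 3 `CC(C(=O)NCc1ccc(C(F)(F)F)cc1SC1CCCC1)c1ccc(NS(C)(=O)=O)c(F)c1` gives 0.3 nM. Compound 3 sits at the low end of these numbers: the step of a 4.3-fold lower number from compound 1 to compound 3 (0.64 log units; beyond the scatter) is beyond the scatter, while a 2.0-fold lower number from compound 2 to compound 3 (0.30 log units; within the scatter) is within it. Compound 4 `CC(C(=O)NCc1ccc(C(F)(F)F)cc1SC1CCCCC1)c1ccc(NS(C)(=O)=O)c(F)c1` differs from compound 3 by cyclohexyl in place of cyclopentyl on a sulfur. No measured step changes only the ring on the sulfur; the steps shown swap the whole group, so they give no direct guide, and no change beyond the scatter is expected in this assay. The expected step is no change at the digits printed from compound 3 to compound 4 (within the scatter), and compound 4 is estimated at 0.3 nM, with a range from 0.1 nM to 0.9 nM.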

Compound 4, inhibition constant: 0.5 nM
Compound 4: the middle estimate sits 1.7-fold (0.22 log units) below what was measured; measured number inside the range.
By their numbers in this assay, from the lowest: compounds 3, 4 and 2 (each within the scatter of the next); then compound 1.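

In this assay, cyclohexyl in place of cyclopentyl on a sulfur gives a 1.7-fold higher number from compound 3 to compound 4 (0.22 log units; within the scatter) and so shows that this position accepts the larger ring without a change that can be told from the scatter. Against the cyclopentyloxy group the cyclohexylsulfanyl group gives a 1.2-fold lower number from compound 2 to compound 4 (0.08 log units; within the scatter) and so stands level with it, while against the 4,4-dimethylpiperidin-1-yl group it gives a 2.6-fold lower number from compound 1 to compound 4 (0.41 log units; beyond the scatter) as a modest step to a lower number. Nothing measured here explains these numbers.

From the compounds shown here alone, whether a smaller cyclobutyl ring, an open butyl chain or a piperidine ring carrying an amine nitrogen on the sulfur would hold these numbers stays open. So does how far ring size can grow at this position, since only cyclopentyl and cyclohexyl can be compared here.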